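The source may hold more compounds than are shown below. What is called first, only, known or untested is meant among the compounds shown, and "the series" means these compounds.

Measured compounds in an ADME assay for permeability, using PAMPA, with a stated time of 30 min, at pH 7.4; a higher number here means that the compound crosses the layer faster, a lower number that the compound crosses the layer more slowly:
compound 1 `c1ccc(Oc2ccc3c(NCCCNCc4ccco4)ccnc3c2)cc1` gives 317 10^-6 cm/s;
compound 2 `COc1cccc(CNCCCNc2ccnc3cc(Oc4ccccc4)ccc23)c1O` gives 317 10^-6 cm/s;
compound 3 `COc1ccc(F)cc1CNCCCNc1ccnc2cc(-c3ccc(C(C)(C)C)cc3)ccc12` gives 237 10^-6 cm/s.

Compound 1 stands level with compound 2 at the digits shown, and the pair sits at the top of the three numbers; compound 3 is within the scatter of both. Among the measured compounds shown here, the one single-point step, no change at the digits printed from compound 1 to compound 2 (within the scatter), concerns the group on the amine chain, not the phenoxy ring, so no measured step bears on the change now considered. Compound 4 `Clc1ccc(Oc2ccc3c(NCCCNCc4ccco4)ccnc3c2)cc1` differs from compound 1 by chloro in place of hydrogen on an aromatic carbon. For the measured compounds named here, with no step to guide it, the expectation for compound 4 is no change beyond the scatter, a 1.0-fold higher number from compound 1 to compound 4 (0.00 log units; within the scatter), giving an estimated 320 10^-6 cm/s within 200 10^-6 cm/s to 480 10^-6 cm/s.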

Compound 4, apparent permeability: 317 10^-6 cm/s
For compound 4 the middle estimate is 1.0-fold (0.00 log units) above the measured one, and the stated range covers the measured number.
By their numbers in this assay, from the lowest: compounds 3, 1, 2 and 4 (each within the scatter of the next).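

In this assay chloro in place of hydrogen on the phenoxy ring, para to a large group, gives no change at the digits printed from compound 1 to compound 4 (within the scatter). Among the compounds shown here, this is the first measured step at this ring, as the earlier step concerned only the group on the amine chain, and it shows that phenoxy to 4-chlorophenoxy leaves the read-out within the scatter with the furan-2-yl chain held constant. Nothing available explains why the number stays level.

The compounds shown leave open whether a carboxylic acid, an amine or a methoxy group at this same carbon would also stay within the scatter. They also leave open whether chloro would behave alike with the 2-hydroxy-3-methoxyphenyl group of compound 2 on the chain.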